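Swapping the chlorophenyl for an ethoxyphenyl on the amine

This account rests on a few compounds, and the source may have more. Where it says the series, first, only, none or still open, it means among the compounds named here.

Three analogues sharing one core have been measured. Compound 1 `O=C1C=C(Nc2ccc(I)cc2)C(=O)c2c1nc1n2[C@H]2OC[C@@H](O)[C@H]2OC1` gives 1400 nM in a functional assay on MGC-803 cells (Homo sapiens) for inhibition, read by sulforhodamine B assay; a higher number here means a weaker inhibitor, a lower number a stronger inhibitor; compound 2 `COc1cccc(NC2=CC(=O)c3c(nc4n3[C@H]3OC[C@@H](O)[C@H]3OC4)C2=O)c1` gives 1790 nM; compound 3 `O=C1C(Nc2cccc(Cl)c2)=CC(=O)c2c1nc1n2[C@H]2OC[C@@H](O)[C@H]2OC1` gives 1530 nM. Compound 3 stands second highest of the three numbers, yet all three lie within the scatter of one another, so they cannot be told apart. The step to compound 4 `CCOc1ccc(NC2=CC(=O)c3c(nc4n3[C@H]3OC[C@@H](O)[C@H]3OC4)C2=O)cc1` is 4-ethoxyphenyl in place of 3-chlorophenyl on an amine nitrogen. Going by the values given here, the only measured step touching a change on that phenyl ring is a 1.2-fold lower number from compound 2 to compound 3 (0.07 log units; within the scatter), which stayed within the scatter. Exchanging one substituted phenyl for another therefore gives no ground to expect movement beyond the scatter, and the estimated step of a 1.0-fold lower number from compound 3 to compound 4 (0.01 log units; within the scatter) is expected to be small. Compound 4 is expected near 1500 nM, with a range of 700 nM to 3500 nM.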

Compound 4, half-maximal inhibitory concentration: 2090 nM
Compound 4: the middle estimate sits 1.4-fold (0.14 log units) below what was measured, within the range that was stated.
By their numbers in this assay, from the lowest: compounds 1, 3, 2 and 4 (each within the scatter of the next).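

In this assay, the amine nitrogen accepts a larger substituted phenyl without a readable shift: 4-ethoxyphenyl for 3-chlorophenyl gives a 1.4-fold higher number from compound 3 to compound 4 (0.14 log units; within the scatter), and 4-ethoxyphenyl for 3-methoxyphenyl gives a 1.2-fold higher number from compound 2 to compound 4 (0.07 log units; within the scatter). Thus the ethoxy chain, in the 4-ethoxyphenyl group, leaves compound 4 indistinguishable from both neighbours. Nothing available explains why these numbers stay together. Still open, going by these compounds, is whether a phenyl ring carrying a carboxylic acid or an amine would move the number beyond the scatter. A cyclohexyl group in place of the phenyl ring would test whether the aromatic ring matters at all.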